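This account rests on a few compounds, and the source may have more. Where it says the series, first, only, none or still open, it means among the compounds named here.

The measured compounds:
- compound 1, `FC(F)(F)c1cccc(NC(=S)Nc2ccc(I)cc2)c1`, gives 9400 nM in an ADME assay on BHK cells (Mesocricetus auratus) for cytotoxicity, read by MTT assay, with a stated time of 96 h; a higher number here means that more compound is tolerated, a lower number that less compound is tolerated
- compound 2, `Fc1ccc(NC(=S)Nc2cccc(C(F)(F)F)c2)cc1`, gives 26000 nM in this assay
- compound 3, `FC(F)(F)c1cccc(NC(=S)Nc2ccccc2)c1`, gives 41000 nM in this assay

Compound 3 holds the highest of the three numbers in this assay. Its distance from compound 2 is small: a 1.6-fold higher number from compound 2 to compound 3 (0.20 log units; within the scatter) lies within the scatter, so no order between these two can be claimed. Its distance from compound 1 is clearer: a 4.4-fold higher number from compound 1 to compound 3 (0.64 log units; beyond the scatter) goes beyond the scatter, as does a 2.8-fold higher number from compound 1 to compound 2 (0.44 log units; beyond the scatter).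

Compound 4, `CSCCCNC(=S)Nc1cccc(C(F)(F)F)c1`, departs from compound 3 by 3-(methylsulfanyl)propyl in place of phenyl on an amide-type nitrogen. Every measured step concerns a halogen on an aromatic carbon of the shared core; none touches the group on the amide-type nitrogen, and none exchanges a ring for a chain. Among the measured compounds shown here, no measured step therefore bears directly on this change, and the expectation rests on compound 3 alone with wide uncertainty. Compound 4 is expected to give about 40000 nM, within a range of 13000 nM to 120000 nM in this assay. That estimate means a step of a 1.0-fold lower number from compound 3 to compound 4 (0.01 log units; within the scatter), which is expected to stay within the scatter.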

Compound 4, half-maximal cytotoxic concentration: > 100000 nM
Compound 4 was reported as a limit; the forecaster's own chance of this, stated with the estimate: 20%; at least 2.5-fold (0.39 log units) between middle value and limit.
By their numbers in this assay, from the lowest: compound 1; then compounds 2 and 3 (each within the scatter of the next). At a limit, above all of these: compound 4.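

Compound 4 is reported in this assay only as a limit, not as a number: the limit of > 100000 nM in this assay, at which 1 of the 4 values shown sits.

The earlier compounds shown here differed only at an aromatic carbon of the shared core, whereas here the group on the amide-type nitrogen changes, and 3-(methylsulfanyl)propyl in place of phenyl gives an at least 2.4-fold higher number from compound 3 to compound 4 (0.38 log units; beyond the scatter). Against the halogen-bearing rings, the same chain gives an at least 3.8-fold higher number from compound 2 to compound 4 (0.58 log units; beyond the scatter) and an at least 10-fold higher number from compound 1 to compound 4 (1.02 log units; beyond the scatter), so at this position an open chain is tolerated better than each of the three aromatic rings shown.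

The compounds shown leave open whether this step follows from losing the ring or from the sulfur in the chain, which a plain butyl chain or a benzyl group could help separate. As far as these compounds go, how far the value of compound 4 lies past its limit also remains open.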